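This account rests on a few compounds, and the source may have more. Where it says the series, first, only, none or still open, it means among the compounds named here.

Measured compounds in a functional assay on HepG2 cells (Homo sapiens) for antiproliferative activity, read by MTT assay, with a stated time of 48 h; a lower number here means a stronger inhibitor, a higher number a weaker inhibitor:
compound 1, `Cc1ccc(NC(=O)Nc2cccc(CNc3nccnc3Cl)c2)cc1C`: 10700 nM
compound 2, `O=C(Nc1cccc(CNc2nccnc2Cl)c1)NC1CCCCC1`: > 40000 nM, a limit of the assay
compound 3, `O=C(Nc1cccc(CNc2nccnc2Cl)c1)Nc1ccc(Cl)cc1Br`: 6720 nM

Compound 3 carries the lowest of the two numbers in this assay; its nearest neighbour is compound 1, the gap being a 1.6-fold lower number from compound 1 to compound 3 (0.20 log units; within the scatter), so the two are not separated. For compound 2 only the limit of > 40000 nM in this assay, at which 1 of the 3 values shown sits, is known.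

Compound 4, `Cc1ccc(NC(=O)Nc2cccc(CNc3nccnc3Cl)c2)c(C)c1`, differs from compound 3 by 2,4-dimethylphenyl in place of 2-bromo-4-chlorophenyl on an amide-type nitrogen.

Among the measured compounds shown here, two measured steps bear on this. Moving from one substituted phenyl to another on the amide-type nitrogen gave a 1.6-fold lower number from compound 1 to compound 3 (0.20 log units; within the scatter), within the scatter. Replacing cyclohexyl by a substituted phenyl gave an at least 5.9-fold lower number from compound 2 to compound 3 (0.77 log units; beyond the scatter), beyond it. The step to compound 4 keeps a substituted phenyl on that nitrogen, and compound 1 already shows that a dimethylphenyl there gives 10700 nM. A step within the scatter is therefore expected in this assay, with compound 4 landing close to compound 1 and compound 3.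

Compound 4 is estimated at 9000 nM, with a range of 4000 nM to 22000 nM, which corresponds to an expected step of a 1.3-fold higher number from compound 3 to compound 4 (0.13 log units; within the scatter).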

Compound 4, half-maximal inhibitory concentration: 9290 nM
Compound 4: the middle estimate sits 1.0-fold (0.01 log units) below what was measured; low and high end bracket the measured number.
By their numbers in this assay, from the lowest: compounds 3, 4 and 1 (each within the scatter of the next). At a limit, above all of these: compound 2.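

In this assay, 2,4-dimethylphenyl in place of 2-bromo-4-chlorophenyl on the amide-type nitrogen gives a 1.4-fold higher number from compound 3 to compound 4 (0.14 log units; within the scatter) and so does not separate the two methyl groups from the two halogens in this matched pair. The two dimethylphenyl isomers are not separated either, with a 1.2-fold lower number from compound 1 to compound 4 (0.06 log units; within the scatter) for 2,4-dimethylphenyl in place of 3,4-dimethylphenyl. A further substituted phenyl now stands apart from cyclohexyl, with an at least 4.3-fold lower number from compound 2 to compound 4 (0.63 log units; beyond the scatter) as the step, and that comparison rests on a value that is only a limit: the limit of > 40000 nM in this assay, at which 1 of the 4 values shown sits.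

Open, from the compounds shown here alone, is whether a phenyl carrying a carboxylic acid or a dimethylamino group on the amide-type nitrogen would separate from compound 1, compound 3 and compound 4. Also open, going by these compounds, is whether a benzyl group there would read like these substituted phenyls or like cyclohexyl.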